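Carbonyl substituent variation on the shared core

The compounds below may be only part of what the source reports. "The series", "measured", "known", "first", "only" and "open" are said of these compounds alone.

Compound 3 `Cc1nc(S(C)(=O)=O)ccc1Oc1ncnc(OC2CCN(C(=O)SC3CCC3)CC2)c1F` gives 81% in a functional assay on isolated protein for inhibition of Glucose-dependent insulinotropic receptor (Rattus norvegicus), read by HTRF and cAMP accumulation (a lower number here means a smaller maximal response, a higher number a larger maximal response), level with compound 1 `Cc1nc(S(C)(=O)=O)ccc1Oc1ncnc(OC2CCN(C(=O)OC3CCC3)CC2)c1F` at 81%; together these are the lowest of the three numbers. Compound 2 `Cc1nc(S(C)(=O)=O)ccc1Oc1ncnc(OC2CCN(C(=O)O[C@@H](C)CF)CC2)c1F` at 84% sits furthest off, yet a number 3 percentage points lower from compound 2 to compound 3 (within the scatter). Compound 4 `Cc1nc(S(C)(=O)=O)ccc1Oc1ncnc(OC2CCN(C(=O)c3noc(C(C)(C)F)n3)CC2)c1F` differs from compound 3 in one place: a group of 9 heavy atoms (5 carbon, 2 nitrogen, 1 oxygen, 1 fluorine; one five-membered aromatic ring with 3 hetero atoms) in place of a group of 5 heavy atoms (4 carbon, 1 sulfur; one four-membered non-aromatic ring of carbon only), on a carbonyl carbon. Within the data shown here, the steps that bear on this position are small: no change at the digits printed from compound 1 to compound 3 (within the scatter), and a number 3 percentage points higher from compound 1 to compound 2 (within the scatter). Among the measured compounds shown here, no measured step replaces the group on the carbonyl carbon with an aromatic ring, so that part is uncharted. On the evidence of these flat steps the expected step is a number 1 percentage points higher from compound 3 to compound 4 (within the scatter), none beyond the scatter. Compound 4 is therefore estimated at 82%, with a range of 68% to 96%.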

Compound 4, largest response reached (reported as efficacy), in percent of the reference or control that the assay uses: 74%
Compound 4: middle estimate off by 8 percentage points, on the high side, and the stated range covers the measured number.
By their numbers in this assay, from the lowest: compounds 4, 1, 3 and 2 (each within the scatter of the next).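

Working notes: an aromatic ring on the carbonyl carbon, a change the earlier compounds did not include, stays within the scatter of all three in this assay: a number 7 percentage points lower from compound 3 to compound 4 (within the scatter), a number 7 percentage points lower from compound 1 to compound 4 (within the scatter) and a number 10 percentage points lower from compound 2 to compound 4 (within the scatter). The flat picture at this position therefore extends to a five-membered aromatic ring with 3 hetero atoms, although this is a single example. No measured evidence bears on these steps.

As far as these compounds go, how an amine or a phenyl ring on the carbonyl carbon would read in this assay remains open. Also open, from the compounds shown here alone, is whether the five-membered ring without its fluorine would read the same.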